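The source may report more compounds than this note shows. Statements on the series, on what has been measured and on what is new or still open speak of the compounds shown alone.

Measured so far in a functional assay on NCI-H157 cells (Homo sapiens) for antiproliferative activity, read by sulforhodamine B assay, with a stated time of 48 h, tested at 10 uM; a lower number here means less inhibition of growth, a higher number more inhibition of growth at the concentration tested:
- Compound 1 `Cc1occc1-c1nn2c(-c3ccncc3)nnc2s1`: 55.1%
- Compound 2 `Fc1ccc(OCc2nn3c(-c4ccncc4)nnc3s2)cc1`: 28.5%

Compound 2, at 28.5%, holds the lower of the two numbers, and its gap from compound 1, at 55.1%, lies beyond the usual scatter of such measurements. Compound 3 `COc1ccc(OCc2nn3c(-c4ccncc4)nnc3s2)cc1` differs from compound 2 in one place: methoxy in place of fluoro on an aromatic carbon. Methoxy stands in place of fluoro on an aromatic carbon, turning 4-fluorophenyl into 4-methoxyphenyl. For the measured compounds named here, no measured pair shows a change of this kind, so the data give no direct size for it. In this assay, no step beyond the scatter is expected in either direction, and the expected shift is small: a number 2.5 percentage points higher from compound 2 to compound 3 (within the scatter). For compound 3, the estimated value is 31%, with an expected range of 13% to 50%.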

Compound 3, percent growth inhibition at one concentration: 65.6%
Beside the measured number, compound 3's estimate is 34.6 percentage points below it; the measured number lies above the stated range.
By their numbers in this assay, from the lowest: compound 2; then compound 1; then compound 3.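

In this assay, replacing fluoro with methoxy on this aromatic carbon gives a number 37.1 percentage points higher from compound 2 to compound 3 (beyond the scatter) and is therefore far from a neutral swap. This shows that one position, para to a large group, can strongly change growth inhibition while the rest of the molecule stays the same. The data offer no measurement that accounts for this difference, so the step stands as an observation without an established cause.

As far as these compounds go, with only fluoro and methoxy compared here, it remains open whether methoxy is unusually favorable or whether an amine, a hydroxyl or a longer ether such as ethoxy would do as well or better. From the compounds shown here alone, it is also open whether this difference, seen at a single concentration in one cell line, would hold across other concentrations or other cells.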